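A few compounds are considered here, and "the series" means these few. Any claim that something is new, unique, unknown or untested is made for them only; others in the source may bear on it.

Among the measured compounds shown here, compound 2 `C=CCc1cc(C(C)=O)c(O)cc1OCCCCCC` stands highest of the three numbers known so far: in an assay on isolated protein for inhibition of leukotriene B4 receptor 1 (Homo sapiens), tested at 10 uM (a higher number here means more inhibition at the concentration tested (going by the name of the read-out), a lower number less inhibition), compound 2 gives 50%. The nearest value belongs to compound 3 `CCCc1cc(C(C)=O)c(O)cc1OCCCCC(=O)O`, which in this assay gives 11%, lower by an amount beyond the scatter, and the furthest to compound 1 `CC(=O)c1ccc(OCCCCC#N)cc1O`, which in this assay gives 0%. Compound 4 `C=CCc1cc(C(C)=O)c(O)cc1OCCCCCC(=O)NO` has not been measured yet. It differs from compound 2 by hydroxycarbamoyl in place of methyl on a saturated chain carbon, five bonds along the chain from an oxygen on an aromatic ring. For the measured compounds named here, no measured pair shows this exact change, so the expectation rests on the compounds at hand: compound 3 with a chain ending in a carboxylic acid gives 11% and compound 1 with a chain ending in a nitrile gives 0%, which points downward. The step from compound 2 to compound 4 is expected to be a number 30 percentage points lower from compound 2 to compound 4 (beyond the scatter). Compound 4 is estimated at 20%, in a range from 5% to 45%.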

Compound 4, a percentage reported as inhibition, at one concentration (the size of the read-out at that concentration, not a potency): 85%
Beside the measured number, compound 4's estimate is 65 percentage points below it; the whole stated range lies below it.
By their numbers in this assay, from the lowest: compound 1; then compound 3; then compound 2; then compound 4.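

At this place, on a saturated chain carbon, five bonds along the chain from an oxygen on an aromatic ring, hydroxycarbamoyl in place of methyl gives a number 35 percentage points higher from compound 2 to compound 4 (beyond the scatter) in this assay. This is the first change in a single place among these compounds, and it shows that the chain end accepts a much larger group with a gain in inhibition. Nothing available explains the rise.

As far as these compounds go, whether the whole hydroxycarbamoyl group is needed remains open. A primary amide or a methyl ester at this place, or a longer chain carrying hydroxycarbamoyl, would test this.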